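A few compounds are considered here, and "the series" means these few. Any claim that something is new, unique, unknown or untested is made for them only; others in the source may bear on it.

Of the compounds shown here, two with a shared core have been measured in a functional assay on HEK293 cells for agonist activity at Bile acid receptor (Homo sapiens), read by a luciferase reporter; on this read-out lower numbers stand for an effect already at smaller amounts and higher numbers for an effect only at larger amounts of compound. Compound 1 `CC(C)c1onc(-c2c(Cl)cccc2Cl)c1COc1ccc(N(C)Cc2cccc(C(=O)NS(C)(=O)=O)c2)c(C(F)(F)F)n1` gives 20 nM in this assay. Within the data shown here, compound 2 `CC(Nc1ccc(C(=O)O)cc1)c1ccc(OCc2c(-c3c(Cl)cccc3Cl)noc2C2CC2)nc1C(F)(F)F` gives 202 nM, which is the higher of the two numbers known so far; its nearest neighbour is compound 1, whose number lies lower by a step beyond the usual scatter. Among the measured compounds shown here, no pair of these measured compounds differs in a single place, so the account cannot point to any measured step that isolates one change.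

Compound 3 `CC(Oc1cccc(C(=O)O)c1)c1ccc(OCc2c(-c3c(Cl)cccc3Cl)noc2C2CC2)nc1C(F)(F)F` is not yet measured. It differs from compound 2 in one place: 3-carboxyphenoxy in place of (4-carboxyphenyl)amino on a saturated chain carbon bound to an aromatic carbon and a saturated chain carbon. For the measured compounds named here, in this step both the link to the ring and the position of the carboxylic acid on that ring are altered at the same time, and the known pair gives no measured step that resembles it. The account therefore expects for compound 3 a step of a 1.5-fold higher number from compound 2 to compound 3 (0.17 log units; within the scatter), with no clear direction beyond the scatter. Compound 3 is thus estimated to give 300 nM in this assay, within a range from 75 nM to 1200 nM.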

Compound 3, half-maximal effective concentration: 58 nM
Compound 3: middle estimate off by 5.2-fold (0.71 log units), on the high side; measured number outside the range, below it.
By their numbers in this assay, from the lowest: compound 1; then compound 3; then compound 2.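

In this assay, among these compounds, 3-carboxyphenoxy in place of (4-carboxyphenyl)amino on a saturated chain carbon bound to an aromatic carbon and a saturated chain carbon gives a 3.5-fold lower number from compound 2 to compound 3 (0.54 log units; beyond the scatter), the first measured step here that isolates one place. It shows that this position is not indifferent to what it carries: both groups count 10 heavy atoms and one six-membered aromatic ring of carbon only, yet the read-out separates them by more than the scatter, and the entering group, with its 1 hydrogen-bond donor against 2 in the leaving group, gives the lower number. No measurement is available that would explain this shift, so it stands as an observation about this one pair.

The step alters the link to the ring and the place of the carboxylic acid together, so it remains open which of the two accounts for the shift, a question that an oxygen link with the acid placed as in compound 2, or a nitrogen link with the acid placed as in compound 3, would settle. Going by these compounds, it also remains open how this position would respond to a tetrazole or a primary amide in place of the carboxylic acid.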